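Pyridin-2-yl in Place of Phenyl: Compound 1 to Compound 3

A few compounds are considered here, and "the series" means these few. Any claim that something is new, unique, unknown or untested is made for them only; others in the source may bear on it.

Compound 1 `Cc1cc(C)c2cc(C#N)c(NCCNC(=O)c3ccccc3)nc2c1`: 100000 nM
Compound 2 `Fc1ccc(CN2CCc3nc(-c4ccccn4)nc(NCCCN4CCCC4)c3C2)cc1`: 200 nM

In an assay on cells with Cystic fibrosis transmembrane conductance regulator variant F508del (Homo sapiens) as the target, read by fluorescence, with stated times of 24 h and 30 min (on this read-out lower numbers stand for an effect already at smaller amounts and higher numbers for an effect only at larger amounts of compound), compound 1 gives 100000 nM, the higher of the two numbers shown. Compound 2 gives 200 nM, and the gap between these two values lies beyond the scatter. Compound 3 `Cc1cc(C)c2cc(C#N)c(NCCNC(=O)c3ccccn3)nc2c1` differs from compound 1 by pyridin-2-yl in place of phenyl on a carbonyl carbon. Within the data shown here, no measured pair shows this change, so no step size is on record. The step of a 1.3-fold lower number from compound 1 to compound 3 (0.10 log units; within the scatter) is expected to stay within the scatter, because compound 1 already sits at 100000 nM. Compound 3 is estimated at 80000 nM, between 20000 nM and 200000 nM.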

Compound 3, half-maximal effective concentration: 100000 nM
Beside the measured number, compound 3's estimate is 1.3-fold (0.10 log units) below it, within the range that was stated.
By their numbers in this assay, from the lowest: compound 2; then compounds 1 and 3 (each within the scatter of the next).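

In this assay, among these compounds, the first reading at this position, pyridin-2-yl in place of phenyl on a carbonyl carbon, shows no change at the digits printed from compound 1 to compound 3 (within the scatter). The one hydrogen-bond acceptor that enters with the ring nitrogen therefore leaves compound 3 at 100000 nM, level with compound 1. No supporting measurement bears on this result. Still open, from the compounds shown here alone, is whether a carboxylic acid or an amine on this aromatic ring, or a longer chain in its place, would move the number at all.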